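Adding a hydroxy to compound 2

A few compounds are considered here, and "the series" means these few. Any claim that something is new, unique, unknown or untested is made for them only; others in the source may bear on it.

In an ADME assay on HEK293 cells (Homo sapiens) for cytotoxicity, read by resazurin assay, with a stated time of 24 h (a lower number here means that less compound is tolerated, a higher number that more compound is tolerated), compound 2 `CCN(CC)C(=O)c1c(O)cccc1CCc1ccc2ccccc2c1` gives > 100000 nM, which is a limit and not a number. Its parent acid, compound 1 `O=C(O)c1c(O)cccc1CCc1ccc2ccccc2c1`, gives > 100000 nM, again a limit. These two compounds therefore share one end of the scale: the limit of > 100000 nM in this assay, at which 2 of the 3 values shown sit. Compound 3 `CCN(CC)C(=O)c1c(CCc2ccc3ccccc3c2)cccc1OC`, by contrast, gives a real number of 85700 nM.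

Compound 4 `CCN(CC)C(=O)c1c(O)cc(O)cc1CCc1ccc2ccccc2c1` differs from compound 2 in one place: hydroxy in place of hydrogen on an aromatic carbon. The new hydroxy takes the place of a hydrogen on an aromatic carbon, para to the diethylcarbamoyl group.

Neither measured step tests this exact change, so both offer only indirect guidance. For the measured compounds named here, the first gives a step that the two limits leave unreadable from compound 1 to compound 2, which provides no usable size. The second gives an at least 1.1-fold lower number from compound 2 to compound 3 (0.06 log units; that floor lies within the scatter), and it bears on the question only loosely, as another small change on the same aromatic ring. Its floor lies within the usual scatter, so it gives no reason to expect a real shift in this assay.

The expected result is therefore no change beyond the scatter, and another limit is quite possible. The estimated step is a number no higher from compound 2 to compound 4 (the limit leaves the size open). For compound 4, the estimated value is 100000 nM, with an expected range from 45000 nM to 200000 nM.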

Compound 4, half-maximal cytotoxic concentration: 30600 nM
Compound 4: the middle estimate sits 3.3-fold (0.51 log units) above what was measured; the measured number lies below the stated range.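

In this assay, for the compounds shown here, the earlier steps showed nothing beyond the scatter, but this change does give a clear step, with an at least 3.2-fold lower number from compound 2 to compound 4 (0.51 log units; beyond the scatter) as the hydroxy enters on the aromatic carbon para to the diethylcarbamoyl group. This position is therefore not silent: a single added hydroxy, meta to the existing hydroxy group and meta to the large group, is enough to make the cells tolerate less compound, although this rests on one pair of compounds only. The step is only a floor, and its true size could be larger, because compound 2 stands at the end of the scale and not at a real number: the limit of > 100000 nM in this assay, at which 2 of the 4 values shown sit.

The compounds shown leave open whether an amine or a fluorine atom on this same aromatic carbon would lower the number as well, or whether the step belongs to the hydroxy alone. They also leave open whether the same added hydroxy would lower the number when the diethylcarbamoyl group is replaced by the carboxylic acid of compound 1.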